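The compounds below may be only part of what the source reports. "The series", "measured", "known", "first", "only" and "open" are said of these compounds alone.

Working notes on the series. The shared core carries a benzyl-type group on the ring nitrogen, and this group is where the three measured compounds differ. Compound 1 `COc1ccc(N2C(=O)N(Cc3ccc(F)cc3Cl)c3ccccc3S2(=O)=O)cc1OC` gives 25.1 nM in an assay on HEK293 cells for displacement of a labelled ligand from Orexin receptor type 2 (Homo sapiens), read by scintillation counting, with a stated time of 90 min; on this read-out higher numbers stand for weaker inhibition and lower numbers for stronger inhibition. Compound 2 `COc1cc(F)c(CN2C(=O)N(c3ccc(OC)c(OC)c3)S(=O)(=O)c3ccccc32)c(F)c1` gives 0.501 nM in this assay, and compound 3 `COc1ccc(N2C(=O)N(Cc3c(F)cccc3Cl)c3ccccc3S2(=O)=O)cc1OC` gives 0.794 nM. The steps are a 50-fold lower number from compound 1 to compound 2 (1.70 log units; beyond the scatter) and a 32-fold lower number from compound 1 to compound 3 (1.50 log units; beyond the scatter), while a 1.6-fold higher number from compound 2 to compound 3 (0.20 log units; within the scatter). Compound 3 thus sits with compound 2 at the strong end of the three numbers, far from compound 1.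

Compound 4 `COc1ccc(N2C(=O)N(Cc3c(F)cc(F)cc3Cl)c3ccccc3S2(=O)=O)cc1OC` differs from compound 3 by fluoro in place of hydrogen on an aromatic carbon. The new fluoro sits where compound 1 carries its fluoro, so compound 4 combines the substitution of compound 1 with that of compound 3. The bearing steps are a 32-fold lower number from compound 1 to compound 3 (1.50 log units; beyond the scatter), which shows the 2-chloro-6-fluoro pattern carrying the gain, and a 1.6-fold higher number from compound 2 to compound 3 (0.20 log units; within the scatter), which shows that a group at the place para to the large group, as in compound 2, leaves the number within the scatter. No step beyond the scatter is therefore expected, a 1.0-fold higher number from compound 3 to compound 4 (0.00 log units; within the scatter). Compound 4 is estimated at 0.8 nM, between 0.3 nM and 2.5 nM.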

Compound 4, inhibition constant: 1 nM
Compound 4: middle estimate off by 1.3-fold (0.10 log units), on the low side; measured number inside the range.
By their numbers in this assay, from the lowest: compounds 2, 3 and 4 (each within the scatter of the next); then compound 1.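

In this assay, fluoro para to a large group on the 2-chloro-6-fluorobenzyl group gives a 1.3-fold higher number from compound 3 to compound 4 (0.10 log units; within the scatter), so this place accepts fluoro with the number held within the scatter, and a 2.0-fold higher number from compound 2 to compound 4 (0.30 log units; within the scatter) leaves the 2-chloro-4,6-difluorophenyl and 2,6-difluoro-4-methoxyphenyl groups equally placed. With fluoro at this place in both compounds, a 25-fold lower number from compound 1 to compound 4 (1.40 log units; beyond the scatter) shows that fluoro here does not cancel the large gain, which goes with the further fluoro that compound 4 has and compound 1 lacks. No measurement bearing on the reason for these steps is at hand.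

From the compounds shown here alone, whether an amine, a carboxylic acid or a longer chain at this place would stay within the scatter of compound 3 remains open. Also open, going by these compounds, is how far chloro in place of the remaining fluoro would move the number.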